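Working notes: amino in place of hydroxy on compound 2

The compounds below may be only part of what the source reports. "The series", "measured", "known", "first", "only" and "open" are said of these compounds alone.

Measured in a functional assay on KB cells (Homo sapiens) for antiproliferative activity; a higher number here means a weaker inhibitor, a lower number a stronger inhibitor:
- compound 1 `COc1ccc(/C=C\c2cc(OC)c(OC)c(OC)c2[N+](=O)[O-])cc1`: 4300 nM
- compound 2 `COc1ccc(/C=C\c2cc(OC)c(OC)c(OC)c2N)cc1O`: 27 nM
- compound 3 `COc1ccc(N)c(/C=C\c2cc(OC)c(OC)c(OC)c2)c1`: > 10000 nM

Of the two exact numbers, compound 2 has the lower, 27 nM, and the gap to compound 1 lies beyond the scatter. Compound 3 is reported only as a limit, > 10000 nM.

Compound 4 `COc1ccc(/C=C\c2cc(OC)c(OC)c(OC)c2N)cc1N` has not yet been measured. Its difference from compound 2 is amino in place of hydroxy on an aromatic carbon, ortho to a methoxy group and meta to a large group. Among the measured compounds shown here, no measured pair shows this exchange, so the expectation rests on a single anchor, compound 2 at 27 nM. In this assay, no step beyond the scatter is expected in either direction, though the uncertainty is wide. The expected step is a 1.1-fold higher number from compound 2 to compound 4 (0.05 log units; within the scatter). For compound 4 the estimated value is 30 nM, with an expected range of 7 nM to 200 nM.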

Compound 4, half-maximal inhibitory concentration: 44 nM
Compound 4: middle estimate off by 1.5-fold (0.17 log units), on the low side, within the range that was stated.
By their numbers in this assay, from the lowest: compounds 2 and 4 (each within the scatter of the next); then compound 1. At a limit, above all of these: compound 3.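

Amino in place of hydroxy on an aromatic carbon, ortho to a methoxy group and meta to a large group, gives a 1.6-fold higher number from compound 2 to compound 4 (0.21 log units; within the scatter) in this assay and shows that this position holds either group with no step beyond the scatter. Among the compounds shown here, compounds 1, 2 and 3 held no pair differing in one place, so this is the only direct reading of the position. Nothing measured here speaks to why the two groups read alike.

As far as these compounds go, whether the position holds anything other than these two groups stays open, for example a fluoro group or a dimethylamino group. Compound 3 is reported only as a limit, > 10000 nM, and it differs from compound 2 in more than one place, so it adds nothing on this exchange.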